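The source may hold more compounds than are shown below. What is called first, only, known or untested is meant among the compounds shown, and "the series" means these compounds.

Compound 1 `CCCCCCCCCCCCCC(=O)Nc1nnc(S[C@@H]2O[C@H](COC(C)=O)[C@H](OC(C)=O)[C@H](OC(C)=O)[C@H]2OC(C)=O)s1` carries a long saturated acyl chain on the amide of the shared core, with all four hydroxyls of the sugar acetylated. In a functional assay on MDA-MB-231 cells (Homo sapiens) for cytotoxicity, read by MTT assay, with a stated time of 24 h (a lower number here means a stronger inhibitor, a higher number a weaker inhibitor), compound 1 gives 26200 nM. Among the measured compounds shown here, the only other measured compound, compound 2 `C=CCCCCCCCCC(=O)Nc1nnc(S[C@@H]2O[C@H](CO)[C@H](O)[C@H](O)[C@H]2O)s1`, has a shorter unsaturated chain and a free sugar; in this assay compound 2 gives 80600 nM, so compound 1 stands as the lower of the two numbers, and the gap between them lies beyond the scatter.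

Compound 3 `CCCCCCCC(=O)Nc1nnc(S[C@@H]2O[C@H](COC(C)=O)[C@H](OC(C)=O)[C@H](OC(C)=O)[C@H]2OC(C)=O)s1` keeps the acetylated sugar and the core of compound 1 and differs only in the chain: hydrogen in place of hexyl on a saturated chain carbon, seven bonds along the chain from a carbonyl carbon. For the measured compounds named here, no measured pair isolates this change, so its effect must be inferred. Going by the values given here, since the one comparison available pairs a longer chain with the lower number, the step from compound 1 to compound 3 is expected to run toward a higher number, of moderate size, a 2.1-fold higher number from compound 1 to compound 3 (0.32 log units; beyond the scatter). Compound 3 is therefore estimated at 55000 nM in this assay, with a plausible range from 20000 nM to 150000 nM.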

Compound 3, half-maximal inhibitory concentration: 18900 nM
Estimate against measurement, compound 3: 2.9-fold (0.46 log units) above; measured number below the stated range.
By their numbers in this assay, from the lowest: compounds 3 and 1 (each within the scatter of the next); then compound 2.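

In this assay hydrogen in place of hexyl on a saturated chain carbon, seven bonds along the chain from a carbonyl carbon, amounts to a 1.4-fold lower number from compound 1 to compound 3 (0.14 log units; within the scatter) and so does not separate the two compounds, with the acetylated sugar and the shared core held fixed. Among the compounds shown here, this is the first reading of the chain on its own, since compound 2 differs from compound 1 in both the chain and the sugar, and it shows that, between these two saturated chains on this acetylated sugar, removing hexyl leaves the number within the scatter. No measurement of any other kind is at hand to account for this result.

The compounds shown leave open whether a longer chain than that of compound 1, or an amine or a carboxylic acid at the far end of the chain, would give a step beyond the scatter. They also leave open what the acetyl groups contribute, and what the terminal alkene of compound 2 contributes, since no pair shown changes either of these in one place.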